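The compounds below may be only part of what the source reports. "The series", "measured", "known", "first", "only" and "open" are said of these compounds alone.

Measured so far:
- compound 1, `O=C(/C=C/c1cccc(O)c1)c1cccc(-n2cc(-c3ccc(Cl)cc3)[nH]c2=O)c1`: in a functional assay on NCI-H522 cells (Homo sapiens) for inhibition (on this read-out higher numbers stand for weaker inhibition of growth and lower numbers for stronger inhibition of growth), compound 1 gives 1650 nM
- compound 2, `COc1ccc(-c2cn(-c3cccc(C(=O)/C=C/c4ccc(O)c(OC)c4)c3)c(=O)[nH]2)cc1`: in this assay compound 2 gives 3480 nM

Compound 2 holds the highest of the two numbers in this assay; the nearest is compound 1, whose number is lower by a step beyond the usual scatter. Compounds 1 and 2 differ from one another in more than one place, so their gap cannot be assigned to any single change.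

Compound 3, `COc1cc(/C=C/C(=O)c2cccc(-n3cc(-c4ccc(Cl)cc4)[nH]c3=O)c2)ccc1O`, has not yet been measured in this assay. Against compound 2 it carries chloro in place of methoxy on an aromatic carbon. It thereby shares the chloro-bearing ring with compound 1 and the rest of the molecule with compound 2.

Among the measured compounds shown here, no pair of measured compounds isolates this change, so the direction rests only on the fact that compound 1, the chloro-bearing member, gives 1650 nM, the lower number. A modest move downward is expected, possibly no larger than the scatter. For compound 3 in this assay the estimate is 2300 nM, with a range from 950 nM to 5500 nM. This estimate implies a step of a 1.5-fold lower number from compound 2 to compound 3 (0.18 log units; within the scatter), which is expected to be small.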

Compound 3, concentration for 50% growth inhibition: 2360 nM
The estimate for compound 3 lay 1.0-fold (0.01 log units) below the measured number, and the stated range covers the measured number.
By their numbers in this assay, from the lowest: compounds 1, 3 and 2 (each within the scatter of the next, the first and the last beyond it).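

In this assay chloro in place of methoxy, on an aromatic carbon para to a large group, gives a 1.5-fold lower number from compound 2 to compound 3 (0.17 log units; within the scatter) with the rest of the molecule held as in compound 2, so the change from 4-methoxyphenyl to 4-chlorophenyl now has a step of its own. The other single change, 4-hydroxy-3-methoxyphenyl in place of 3-hydroxyphenyl on the double-bonded chain, gives a 1.4-fold higher number from compound 1 to compound 3 (0.16 log units; within the scatter) with the 4-chlorophenyl group held fixed, so neither change read alone gives a step beyond the scatter, although compound 1 and compound 2, which carry both differences, lie beyond it. No supporting measurement bears on either step.

Going by these compounds, whether a 4-fluorophenyl, 4-trifluoromethylphenyl, 4-aminophenyl or unsubstituted phenyl group at this place would give a step beyond the scatter stays open. Also open, on these data alone, is whether chloro in place of methoxy reads the same when the chain carries 3-hydroxyphenyl, a pairing that would show if the two changes act independently.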